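The source may report more compounds than this note shows. Statements on the series, on what has been measured and on what is new or still open speak of the compounds shown alone.

Compound 3 `Nc1nc(C(F)(F)F)cc2c1[nH]c(=O)n2Cc1ccc(NCCN2CCCC2)nc1` has been tested in an in vitro ADME assay on microsomes from liver (Homo sapiens) for pharmacokinetics (on this read-out higher numbers stand for fast clearance and lower numbers for slow clearance), where compound 3 gives 8.5 mL.min-1.g-1. Its closest neighbour among the measured compounds is compound 2 `Nc1nc(C(F)(F)F)cc2c1[nH]c(=O)n2Cc1ccc(NCCN2CCCCC2)nc1`, which in this assay gives 13 mL.min-1.g-1. These two differ only in the ring at the end of the side chain, and the change from compound 2 to compound 3 is a 1.5-fold lower number from compound 2 to compound 3 (0.18 log units; within the scatter), so the two numbers cannot be told apart. Compound 1 `CN(C)CCN1CCN(c2ccc(Cn3c(=O)[nH]c4c(N)nc(C(F)(F)F)cc43)cn2)CC1` is a third member of the series. In this assay compound 1 gives only a limit, < 8 mL.min-1.g-1, and not a number, as recorded in the limit of < 8 mL.min-1.g-1 in this assay, at which 1 of the 3 values shown sits. The steps from compound 1 to compound 2, an at least 1.6-fold higher number from compound 1 to compound 2 (0.21 log units; that floor lies within the scatter), and from compound 1 to compound 3, an at least 1.0-fold higher number from compound 1 to compound 3 (0.02 log units; that floor lies within the scatter), therefore give a floor only, and both floors lie within the scatter.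

Compound 4 `Nc1nc(C(F)(F)F)cc2c1[nH]c(=O)n2Cc1ccc(NCc2ccccc2)nc1` is the compound not yet measured. It differs from compound 3 by phenyl in place of (pyrrolidin-1-yl)methyl on a saturated chain carbon bound to a nitrogen on an aromatic ring. Within the data shown here, only the step from compound 2 to compound 3 touches the same part of the molecule, and it stayed within the scatter, but none of the measured steps swaps a saturated ring for an aromatic one. The measured series thus offers no clear signal. The expected step is a 1.4-fold higher number from compound 3 to compound 4 (0.15 log units; within the scatter), with wide uncertainty in either direction. In this assay compound 4 is estimated at 12 mL.min-1.g-1, in the range 5 mL.min-1.g-1 to 30 mL.min-1.g-1.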

Compound 4, intrinsic clearance in microsomes: < 8 mL.min-1.g-1
Compound 4 was reported as a limit; the forecaster's own chance of this, stated with the estimate: 15%; at least 1.5-fold (0.17 log units) between middle value and limit.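

Compound 4 puts the first aromatic ring on this saturated chain carbon, and in this assay the swap brings no rise in the number: the reading is an at least 1.0-fold lower number from compound 3 to compound 4 (0.02 log units; that floor lies within the scatter), and against the piperidine analogue it is an at least 1.6-fold lower number from compound 2 to compound 4 (0.21 log units; that floor lies within the scatter). The phenyl group that enters has no hydrogen-bond acceptor and the (pyrrolidin-1-yl)methyl group that leaves has one, so among these compounds a nitrogen-bearing saturated ring at the end of the chain is not needed for a number this low. The step between compound 1 and compound 4 cannot be read, and the two readable steps give only floors within the scatter, because the assay reports limits here and not numbers: the limit of < 8 mL.min-1.g-1 in this assay, at which 2 of the 4 values shown sit.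

From the compounds shown here alone, what stays open is whether the low number goes with the aromatic ring itself or simply with the loss of the ring nitrogen. A cyclohexyl group at this place, saturated and free of nitrogen, could separate the two, as could a pyridyl group, which is aromatic and keeps a ring nitrogen.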